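The compounds below may be only part of what the source reports. "The series", "measured", "known", "first", "only" and "open" are said of these compounds alone.

In a functional assay on the whole organism (strain albino) for inhibition, with Rattus norvegicus as the target, read by paw edema, with stated times of 1 h and 3 h, at a dose of 20 mmol/kg by the intraperitoneal route (on this read-out higher numbers stand for a stronger effect at the one dose given and lower numbers for a weaker effect), compound 1 `N#CC1=C(NC(=O)c2ccccc2O)N(c2ccccc2)C(=O)N2CCCCC(N3CCCC3)C12` gives 65.4%, compound 2 `N#CC1=C(/N=C/Nc2ccc([N+](=O)[O-])cc2)N(c2ccccc2)C(=O)N2CCCCC(N3CCCC3)C12` gives 85.6% and compound 3 `COc1ccc(N/C=N/C2=C(C#N)C3C(N4CCCC4)CCCCN3C(=O)N2c2ccccc2)cc1` gives 50.2%, the lowest of the three numbers. Compound 4 `N#CC1=C(/N=C/Nc2ccccc2)N(c2ccccc2)C(=O)N2CCCCC(N3CCCC3)C12` has not been measured. The change from compound 3 to compound 4 is hydrogen in place of methoxy on an aromatic carbon. For the measured compounds named here, the one step that alters a substituent on this same six-membered aromatic ring of carbon only is a number 35.4 percentage points lower from compound 2 to compound 3 (beyond the scatter); the steps of a number 20.2 percentage points higher from compound 1 to compound 2 (beyond the scatter) and a number 15.2 percentage points lower from compound 1 to compound 3 (beyond the scatter) exchange a larger group and bear less directly. With nitro giving the higher number and methoxy the lower, hydrogen is expected to fall between them, a modest rise a number 11.8 percentage points higher from compound 3 to compound 4 (beyond the scatter) in this assay. Compound 4 is therefore estimated at 62%, within a range from 45% to 80%.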

Compound 4, a percentage reported as inhibition, in the whole organism at one dose (the size of the read-out at that dose, not a potency): 79.3%
Compound 4: middle estimate off by 17.3 percentage points, on the low side; low and high end bracket the measured number.
By their numbers in this assay, from the lowest: compound 3; then compound 1; then compounds 4 and 2 (each within the scatter of the next).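

In this assay, hydrogen in place of methoxy gives a number 29.1 percentage points higher from compound 3 to compound 4 (beyond the scatter), while a number 6.3 percentage points lower from compound 2 to compound 4 (within the scatter) leaves hydrogen and nitro unseparated on this aromatic carbon, so methoxy alone stands apart among the three groups, which the nitro-to-methoxy step could not show. The exchange of the larger group on the double-bonded ring carbon reads a number 13.9 percentage points higher from compound 1 to compound 4 (beyond the scatter), so the unsubstituted phenyl compound also stands clear of the salicyl-type amide compound 1. No measurement here offers a reason for these steps.

Open, on these data alone, is whether ethoxy, a dimethylamino group or chlorine on this aromatic carbon would side with methoxy or with hydrogen and nitro.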